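Amino in place of bromo: compound 3 to compound 4

The compounds below may be only part of what the source reports. "The series", "measured", "known", "first", "only" and "open" are said of these compounds alone.

In a functional assay on KB cells (Homo sapiens) for inhibition (on this read-out lower numbers stand for stronger inhibition and higher numbers for weaker inhibition), compound 1 `Clc1cc(Cl)c2[nH]c(Cl)nc2c1` gives > 100000 nM, which is a limit of the assay and not a number. Compound 2 `OC[C@H]1OC(n2c(Cl)nc3c(Cl)cc(Cl)cc32)[C@H](O)[C@@H]1O` gives 230000 nM, and compound 3 `OC[C@H]1OC(n2c(Br)nc3c(Cl)cc(Cl)cc32)[C@H](O)[C@@H]1O` gives 150000 nM. Among the measured compounds shown here, these two values stand level: the one measured step between them, bromo in place of chloro on an aromatic carbon, is a 1.5-fold lower number from compound 2 to compound 3 (0.19 log units; within the scatter). Compound 3 therefore sits with compound 2 in a weak range of this assay.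

The next change leads to compound 4 `Nc1nc2c(Cl)cc(Cl)cc2n1C1O[C@H](CO)[C@@H](O)[C@H]1O`: amino in place of bromo, on an aromatic carbon between two ring nitrogen atoms (amino in place of bromo on an aromatic carbon). This is the same carbon that changed between compound 2 and compound 3, so that step is the only measured one bearing on the change. For the measured compounds named here, no measured compound carries amino there, which makes it a thin guide. Going by the values given here, with a 1.5-fold lower number from compound 2 to compound 3 (0.19 log units; within the scatter) as the sole precedent, no step beyond the scatter is expected, and the uncertainty runs in both directions. The expected move is a 1.3-fold lower number from compound 3 to compound 4 (0.10 log units; within the scatter). Compound 4 may also return only a limit. For compound 4 the estimated value is 120000 nM, with an expected range of 40000 nM to 300000 nM.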

Compound 4, half-maximal inhibitory concentration: > 300000 nM
Compound 4 gave a limit, no number (the forecaster's own chance of this, stated with the estimate: 35%); at least 2.5-fold (0.39 log units) between middle value and limit.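

Compound 4 returns a limit of the assay in this assay and not a number: the limit of > 300000 nM in this assay, at which 1 of the 4 values shown sits.

Amino on this aromatic carbon, between two ring nitrogen atoms, therefore brings no lower number than either halogen it replaces, and the two steps can be read only as floors: an at least 2.0-fold higher number from compound 3 to compound 4 (0.30 log units; that floor lies within the scatter) and an at least 1.3-fold higher number from compound 2 to compound 4 (0.11 log units; that floor lies within the scatter). Compound 2 and compound 3 spoke only to chloro and bromo on this carbon, and those two stand level, whereas compound 4 shows that a group carrying a hydrogen-bond donor and a hydrogen-bond acceptor, neither of which is counted for bromo, does not move the series out of its weak range.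

From the compounds shown here alone, with only a floor on each step, how far amino lies from the two halogens stays unknown, and a single non-halogen group gives no pattern for this position. Also open, going by these compounds, is how this carbon behaves with methylamino, dimethylamino or a longer alkylamino chain, or with a hydroxyl or a methyl group, any of which would show whether amino stands alone or speaks for a wider set of groups.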